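The source may hold more compounds than are shown below. What is called first, only, known or untested is meant among the compounds shown, and "the series" means these compounds.

Measured in an ADME assay on liver (Mus musculus, strain CD-1) for metabolic stability, read by LC-MS, using microsomes and NADPH, with a stated time of 5 min, tested at 1 uM; on this read-out lower numbers stand for a shorter-lived compound and higher numbers for a longer-lived compound:
- compound 1 `COc1ccc(NC(=O)C(=O)c2cn(C(C)C)c3ccccc23)cn1`: 0.0833 h
- compound 2 `COCC(C)n1cc(C(=O)C(=O)Nc2ccc(OC)nc2)c2ccccc21`: 0.267 h

Compound 2, at 0.267 h, has the higher of these two half-lives. Compound 3 `COc1ccc(NC(=O)C(=O)c2cn(CCOC(C)C)c3ccccc23)cn1` has not yet been measured. It carries 2-isopropoxyethyl in place of 1-(methoxymethyl)ethyl on an aromatic nitrogen.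

Going by the values given here, only one measured step bears on this change: a 3.2-fold higher number from compound 1 to compound 2 (0.51 log units; beyond the scatter). That modest step came from putting methoxy in place of hydrogen on a saturated chain carbon. Among the compounds with values here, it shows that the half-life can respond to a change in this group, but no measured compound carries 2-isopropoxyethyl. A small fall, no larger than the usual scatter, is therefore expected in this assay. The expected change is a 1.7-fold lower number from compound 2 to compound 3 (0.22 log units; within the scatter). For compound 3 the estimated half-life is 0.16 h, with an expected range of 0.07 h to 0.37 h.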

Compound 3, half-life: 0.383 h
The estimate for compound 3 lay 2.4-fold (0.38 log units) below the measured number, and the stated range ends below it.
By their numbers in this assay, from the lowest: compound 1; then compounds 2 and 3 (each within the scatter of the next).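

Replacing 1-(methoxymethyl)ethyl with 2-isopropoxyethyl on the aromatic nitrogen gives a 1.4-fold higher number from compound 2 to compound 3 (0.16 log units; within the scatter), so in this assay the two oxygen-bearing chains cannot be told apart, even though their shapes differ and 2-isopropoxyethyl has more heavy atoms. Going by these compounds alone, measured against the plain isopropyl group, 2-isopropoxyethyl gives a 4.6-fold higher number from compound 1 to compound 3 (0.66 log units; beyond the scatter), which means a second oxygen-bearing chain now stands beyond the scatter from isopropyl, where earlier there was only one such comparison. Nothing available gives a reason for these numbers.

Still open, on these data alone, is whether the oxygen in the chain goes with the longer half-life, or whether chain length alone would give the same result. A carbon-only chain such as pentyl would separate these two readings, and a chain ending in an amine would show how far this position tolerates a different kind of group.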